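Swapping a hydroxy for a methylsulfonyl group

The compounds below may be only part of what the source reports. "The series", "measured", "known", "first", "only" and "open" are said of these compounds alone.

Measured in a functional assay on Caco-2 cells (Homo sapiens) for cytotoxicity, with a stated time of 48 h; a higher number here means a weaker inhibitor, a lower number a stronger inhibitor:
- compound 1 `N#Cc1ccc(-c2cncc(-c3cc4ccc(O)cc4[nH]3)c2)cc1`: 10000 nM
- compound 2 `Oc1ccc(-c2cncc(-c3cc4cc(O)ccc4[nH]3)n2)cc1`: 3000 nM

Among the compounds with values here, only two numbers are available so far. Compound 2, at 3000 nM, is the lower of them and so the stronger inhibitor, and its gap to compound 1 lies beyond the usual scatter of repeated measurements. These two compounds differ in more than one place, so their values show only that gap and cannot be pinned on any single change.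

Compound 3 `CS(=O)(=O)c1ccc(-c2cncc(-c3cc4cc(O)ccc4[nH]3)n2)cc1` keeps the structure of compound 2 except for one swap: methylsulfonyl in place of hydroxy on an aromatic carbon, para to a large group (methylsulfonyl in place of hydroxy on an aromatic carbon). Within the data shown here, no measured pair shows this swap. Among the measured compounds shown here, the only guide is compound 1, which has a nitrile rather than a hydroxy on that carbon-only ring and gives 10000 nM, though it also differs elsewhere. A modest move towards a higher number in this assay therefore seems likely, and the expected step is a 2.0-fold higher number from compound 2 to compound 3 (0.30 log units; within the scatter). For compound 3 the estimated value is 6000 nM, with an expected range from 2000 nM to 20000 nM.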

Compound 3, half-maximal inhibitory concentration: 3000 nM
The estimate for compound 3 lay 2.0-fold (0.30 log units) above the measured number, within the range that was stated.
By their numbers in this assay, from the lowest: compounds 2 and 3 (each within the scatter of the next); then compound 1.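

In this assay, putting methylsulfonyl in place of hydroxy on the aromatic carbon para to a large group gives no change at the digits printed from compound 2 to compound 3 (within the scatter). Within the data shown here, this is the first single change that can be read at this position, as compounds 1 and 2 differ in more than one place and their gap could not be pinned on any one of them. The swap takes the group from 1 heavy atom to 4 and from 1 hydrogen-bond donor to 0, yet compound 2 and compound 3 cannot be told apart in this assay, so at this position neither the donor nor the smaller size is needed to keep the number where it is. No measurement available here gives an explanation for this result.

Among these compounds, with only two groups compared at this position on the same core, it remains open whether an amine, a carboxylic acid or a longer chain there would also leave the number in place. The nitrile of compound 1 offers no answer, as that compound also differs elsewhere.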